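The source may report more compounds than this note shows. Statements on the series, on what has been measured and on what is new or still open speak of the compounds shown alone.

In an ADME assay on HEK293 cells (Homo sapiens) for cytotoxicity, with a stated time of 72 h (on this read-out higher numbers stand for an effect only at larger amounts of compound and lower numbers for an effect already at smaller amounts), compound 2 (`Cc1cc(NC(=O)Nc2ccc(N)cc2)c2ccccc2n1`) gives > 25000 nM, which is a limit of the assay and not a number; it stands at the limit of > 25000 nM in this assay, at which 1 of the 2 values shown sits. Compound 1 (`CCc1ccc(NC(=O)Nc2cc(C)nc3ccccc23)cc1`), which carries ethyl in place of that amino, gives 16000 nM. Within the data shown here, only one measured step bears on the next change, an at least 1.5-fold higher number from compound 1 to compound 2 (0.19 log units; that floor lies within the scatter), and it concerns the same place on the ring. Compound 3 (`Cc1cc(NC(=O)Nc2ccc(C(=O)O)cc2)c2ccccc2n1`) changes that place again, with carboxy in place of amino on an aromatic carbon, para to a large group: carboxy in place of amino on an aromatic carbon. The step from compound 1 offers no measure for carboxy, so no shift beyond the scatter is expected in this assay, in either direction. The expected change is a step that the limit leaves unreadable from compound 2 to compound 3. Compound 3 is estimated at 28000 nM, with an expected range from 14000 nM to 55000 nM.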

Compound 3, half-maximal effective concentration: > 25000 nM
Compound 3: no number, only a limit; the forecaster's own chance of this, stated with the estimate: 70%; the middle value is on the limit's open side.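

In this assay compound 3 gives > 25000 nM, which is a limit of the assay and not a number, so carboxy at this place, para to a large group, yields no more of a readable value than amino did. Carboxy in place of ethyl gives an at least 1.5-fold higher number from compound 1 to compound 3 (0.19 log units; that floor lies within the scatter), so this second change at the same place also shows no shift beyond the scatter. The step between amino and carboxy cannot be read, and what this position shows so far is mostly a limit: the limit of > 25000 nM in this assay, at which 2 of the 3 values shown sit.

On these data alone, it remains open how far compound 2 and compound 3 lie past that limit, so amino and carboxy cannot be ranked. As far as these compounds go, it is also open whether a longer chain such as propyl, or a methoxy group, at this place would give a number that can be read against the ethyl of compound 1.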